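This account rests on a few compounds, and the source may have more. Where it says the series, first, only, none or still open, it means among the compounds named here.

Three compounds share one core and differ only in which hydroxyphenyl group is carried on one side of it. Compound 1 `Oc1ccccc1-c1cc(-c2ccccc2F)cc(-c2ccccc2O)n1` sits at a limit of a functional assay on HeLa cells (Homo sapiens) for inhibition (a lower number here means a stronger inhibitor, a higher number a weaker inhibitor), giving > 50000 nM. Compound 3 `Oc1ccc(-c2cc(-c3ccccc3F)cc(-c3ccccc3O)n2)cc1` likewise sits at a limit, giving > 50000 nM. Compound 2 `Oc1cccc(-c2cc(-c3ccccc3F)cc(-c3ccccc3O)n2)c1` is the only one of the three with a number, giving 31100 nM in this assay. The step of an at least 1.6-fold lower number from compound 1 to compound 2 (0.20 log units; that floor lies within the scatter) and the step of an at least 1.6-fold higher number from compound 2 to compound 3 (0.20 log units; that floor lies within the scatter) are both only floors because the limit of > 50000 nM in this assay, at which 2 of the 3 values shown sit, caps what can be read, and the step that the two limits leave unreadable from compound 1 to compound 3 cannot be read at all. Compound 4 `Oc1cccc(-c2cc(-c3ccccc3F)cc(-c3cccc(O)c3)n2)c1` differs from compound 2 in that (3-hydroxyphenyl in place of 2-hydroxyphenyl on an aromatic carbon). The same exchange, from compound 1 to compound 2, gave an at least 1.6-fold lower number from compound 1 to compound 2 (0.20 log units; that floor lies within the scatter), a floor that lies within the scatter. Compound 4 is therefore expected to land near that number or somewhat lower, an expected step of a 2.1-fold lower number from compound 2 to compound 4 (0.32 log units; beyond the scatter). The estimate for compound 4 in this assay is 15000 nM, with a range from 5000 nM to 50000 nM.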

Compound 4, half-maximal inhibitory concentration: 16000 nM
Compound 4: the middle estimate sits 1.1-fold (0.03 log units) below what was measured; the range from low to high includes it.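

Among the compounds shown here, with compound 4, the exchange of 2-hydroxyphenyl for 3-hydroxyphenyl can for the first time be read between two numbers in this assay: a 1.9-fold lower number from compound 2 to compound 4 (0.29 log units; within the scatter). That step lies within the scatter, so at this place next to the ring nitrogen the exchange does not separate compound 4 from compound 2. The same exchange between compound 1 and compound 2 gave only a floor, and the steps that cannot be read stay that way, because of a single ceiling on the read-out: the limit of > 50000 nM in this assay, at which 2 of the 4 values shown sit.

Open, on these data alone, is whether an amine or a carboxylic acid on this phenyl ring, in place of the hydroxyl, would move the number beyond the scatter. Also open, as far as these compounds go, is what a 3-hydroxyphenyl group in place of the 2-fluorophenyl group would do to compound 4.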